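The source may hold more compounds than are shown below. What is called first, only, known or untested is meant among the compounds shown, and "the series" means these compounds.

Measured so far:
compound 1 `O=C1CSC(c2ccc([N+](=O)[O-])cc2)N1CCN1CCCCC1`: 72%
compound 2 `O=C1CSC(c2ccc(O)cc2)N1CCN1CCCCC1`: 87%

In an ADME assay on Vero cells (Chlorocebus sabaeus) for cytotoxicity, read by neutral red uptake, tested at 197 ug/mL (a lower number here means a stronger effect, a higher number a weaker effect of the compound at the concentration tested), compound 2 gives 87%, the highest of the two numbers, while compound 1 gives 72%; the step of a number 15 percentage points higher from compound 1 to compound 2 (beyond the scatter) is modest but beyond the scatter. Compound 3 `Cc1ccc(C2SCC(=O)N2CCN2CCCCC2)cc1` differs from compound 2 by methyl in place of hydroxy on an aromatic carbon. Among the compounds with values here, no measured step swaps hydroxy for methyl, so the only guide is that one modest step at the same position, which gives no direction for this change. Compound 3 is therefore expected to give an estimated 80%, with a range from 65% to 95%. The expected step is a number 7 percentage points lower from compound 2 to compound 3 (within the scatter), within the scatter.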

Compound 3, a percentage reported as activity, at one concentration (the size of the read-out at that concentration, not a potency): 85%
Compound 3: the middle estimate sits 5 percentage points below what was measured; the range from low to high includes it.
By their numbers in this assay, from the lowest: compound 1; then compounds 3 and 2 (each within the scatter of the next).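

In this assay the change from 4-hydroxyphenyl to 4-methylphenyl gives a number 2 percentage points lower from compound 2 to compound 3 (within the scatter) and so leaves the read-out level, even though a hydrogen-bond donor and acceptor are lost. Methyl in place of nitro gives a number 13 percentage points higher from compound 1 to compound 3 (beyond the scatter) and matches the earlier step from nitro to hydroxy, so compound 1 now stands apart from two compounds that read alike. Nothing measured here explains this difference.

As far as these compounds go, it remains open whether an amine or a carboxylic acid at this position would read like compound 2 and compound 3 or like compound 1.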